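The source may report more compounds than this note shows. Statements on the series, on what has been measured and on what is new or still open speak of the compounds shown alone.

Measured so far in a functional assay for agonist activity at G protein-coupled receptor 88 (Homo sapiens), read by HTRF and cAMP accumulation; on this read-out lower numbers stand for an effect already at smaller amounts and higher numbers for an effect only at larger amounts of compound:
compound 1 `N[C@H](CN(C(=O)[C@@H]1C[C@H]1c1ccccc1)c1ccc(-c2ccccc2)cc1)C1CCCCC1` gives 0.66 nM;
compound 2 `CO[C@H](C)[C@H](N)CN(C(=O)[C@@H]1C[C@H]1c1ccccc1)c1ccc(-c2ccccc2)cc1` gives 0.68 nM;
compound 3 `CC(C)C[C@H](N)CCN(C(=O)[C@@H]1C[C@H]1c1ccccc1)c1ccc(-c2ccccc2)cc1` gives 3 nM.

Among these three, compound 3 has the highest number in this assay, at a modest but real distance from the other two: a 4.5-fold higher number from compound 1 to compound 3 (0.66 log units; beyond the scatter) and a 4.4-fold higher number from compound 2 to compound 3 (0.64 log units; beyond the scatter), while the step of a 1.0-fold higher number from compound 1 to compound 2 (0.01 log units; within the scatter) lies within the scatter. Compound 4 `CC(C)CCNCCN(C(=O)[C@@H]1C[C@H]1c1ccccc1)c1ccc(-c2ccccc2)cc1` is built from the same atoms as compound 3, joined differently: isopentylamino in place of 1-amino-3-methylbutyl on a saturated chain carbon, two bonds along the chain from an amide-type nitrogen. The amine thus becomes a link within the chain rather than a group hanging off it, and the defined stereocentre disappears. Among the measured compounds shown here, no measured pair shows exactly this kind of rearrangement, so the expectation rests on the two steps that reach compound 3, where each change in the region around the amine cost a modest amount of potency. A further modest loss in this assay is expected because a 4.5-fold higher number from compound 1 to compound 3 (0.66 log units; beyond the scatter) and a 4.4-fold higher number from compound 2 to compound 3 (0.64 log units; beyond the scatter) both point that way, though with wide uncertainty. Compound 4 is therefore estimated at 12 nM, ranging from 2.5 nM to 60 nM, an expected step of a 4.0-fold higher number from compound 3 to compound 4 (0.60 log units; beyond the scatter).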

Compound 4, half-maximal effective concentration: 5.1 nM
Beside the measured number, compound 4's estimate is 2.4-fold (0.37 log units) above it, within the range that was stated.
By their numbers in this assay, from the lowest: compounds 1 and 2 (each within the scatter of the next); then compounds 3 and 4 (each within the scatter of the next).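

Moving the amine from a group hanging off the chain to a link within it, with isopentylamino in place of 1-amino-3-methylbutyl and the defined stereocentre gone, gives a 1.7-fold higher number from compound 3 to compound 4 (0.23 log units; within the scatter) in this assay as the whole effect. At this place, then, the amine can sit inside the chain and no defined stereocentre is needed for compound 4 to stay level with compound 3. The larger gaps remain modest but beyond the scatter, with a 7.5-fold higher number from compound 2 to compound 4 (0.88 log units; beyond the scatter) on one side and a 7.7-fold higher number from compound 1 to compound 4 (0.89 log units; beyond the scatter) on the other, so this rearrangement does not reach the lowest numbers of the set.

Still open, from the compounds shown here alone, is whether a methyl group on the linking nitrogen, or a cyclohexyl group in place of the isopentyl end, would close that gap. No measurement at hand explains any of these numbers.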